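Replacing the 4-carboxyphenyl Group of Compound 3

The compounds below may be only part of what the source reports. "The series", "measured", "known", "first", "only" and "open" are said of these compounds alone.

In an ADME assay (liver) for metabolic stability, with Liver microsome (Homo sapiens) as the target, using microsomes (a lower number here means that the compound disappears faster, a higher number that the compound lasts longer), compound 1 `CC(C)c1nc2ccccn2c1C(=O)NCc1ccc(-c2ccccc2)cc1` gives 0.527 h, and compound 2 `CCc1nc2ccc(Cl)cn2c1C(=O)NCc1ccc(-c2ccccc2Cl)cc1` gives 0.648 h, two values within the usual scatter of each other.

Compound 3 `CCc1nc2cc(Cl)ccn2c1C(=O)NCc1ccc(-c2ccc(C(=O)O)cc2)cc1` gives > 2 h, which is a limit of the assay and not a number.

Compound 4 `CCc1nc2cc(Cl)ccn2c1C(=O)NCc1ccc(N2CC3CCCCC3C2)cc1` has not yet been measured. It loses the 4-carboxyphenyl group and gains a group with two non-aromatic rings on the same aromatic carbon: a group of 9 heavy atoms (8 carbon, 1 nitrogen; one five-membered non-aromatic ring with 1 hetero atom, one six-membered non-aromatic ring of carbon only) in place of a group of 9 heavy atoms (7 carbon, 2 oxygen; one six-membered aromatic ring of carbon only), on an aromatic carbon.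

Going by the values given here, no measured pair differs in one place only, so this expectation is rough. It leans on compound 2 at 0.648 h, which also lacks the 4-carboxyphenyl group.

The expected change is an at least 4.0-fold lower number from compound 3 to compound 4 (0.60 log units; beyond the scatter), a fall beyond the usual scatter.

For compound 4, the estimated half-life is 0.5 h, with an expected range from 0.2 h to 1.3 h.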

Compound 4, half-life: 0.248 h
Compound 4: middle estimate off by 2.0-fold (0.30 log units), on the high side; the range from low to high includes it.
By their numbers in this assay, from the lowest: compound 4; then compounds 1 and 2 (each within the scatter of the next). At a limit, above all of these: compound 3.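

Going by these compounds alone, this is the first comparison that changes one place only, the group on an aromatic carbon, and in this assay it gives an at least 8.0-fold lower number from compound 3 to compound 4 (0.90 log units; beyond the scatter). With the rest of the molecule unchanged, the group at this place alone is enough to shift the half-life beyond the usual scatter. The value of compound 3 is a limit of the assay and not a number, so the full size of the step stays unknown: the limit of > 2 h in this assay, at which 1 of the 4 values shown sits.

Going by these compounds, it remains open whether the long half-life goes with the carboxylic acid or with the aromatic ring that carries it. A plain phenyl group at this place on the same core would separate the two.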